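A few compounds are considered here, and "the series" means these few. Any claim that something is new, unique, unknown or untested is made for them only; others in the source may bear on it.

The series shares a common carbocyclic core and is compared in a functional assay on MCF7 cells (Homo sapiens) for antiproliferative activity, read by MTT assay, with a stated time of 48 h; a lower number here means a stronger inhibitor, a higher number a weaker inhibitor. Compound 1 `COC/C1=C/C[C@](C)(CCC=C(C)C)/C=C/[C@@H](OC(=O)C=C(C)C)[C@](C)(OC)/C=C/C1=O` gives 16500 nM in this assay. Compound 3 `CC(C)=CCC[C@]1(C)/C=C/[C@@H](OC(=O)C=C(C)C)[C@](C)(O)/C=C/C(O)/C(C=O)=C\C1` gives 2320 nM in this assay. Compound 2 `CCN(CC)C/C1=C/C[C@](C)(CCC=C(C)C)/C=C/[C@@H](OC(=O)C=C(C)C)[C@](C)(O)/C=C/C1=O` gives 130 nM in this assay, the lowest of the three numbers, with compound 3 nearest and compound 1 furthest, both beyond the scatter. The untested compound 4 `CC(C)=CCC[C@]1(C)/C=C/[C@@H](OC(=O)C=C(C)C)[C@](C)(O)/C=C/C(=O)/C(C(=O)N(C(C)C)C(C)C)=C\C1` differs from compound 2 by diisopropylcarbamoyl in place of (diethylamino)methyl on a double-bonded ring carbon. For the measured compounds named here, with no measured pair mirroring this change, the account leans on compounds 1 and 3, whose numbers sit well above that of compound 2. The step from compound 2 to compound 4 is expected to be a 12-fold higher number from compound 2 to compound 4 (1.06 log units; beyond the scatter) in this assay, toward a weaker inhibitor and beyond the scatter. Compound 4 is estimated at 1500 nM in this assay, within 300 nM to 8000 nM.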

Compound 4, half-maximal inhibitory concentration: 17200 nM
For compound 4 the middle estimate is 11-fold (1.06 log units) below the measured one, and the stated range ends below it.
By their numbers in this assay, from the lowest: compound 2; then compound 3; then compounds 1 and 4 (each within the scatter of the next).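

On this double-bonded ring carbon, diisopropylcarbamoyl in place of (diethylamino)methyl gives a 130-fold higher number from compound 2 to compound 4 (2.12 log units; beyond the scatter) in this assay, a large move toward a weaker inhibitor. For the compounds shown here, the earlier compounds offered no pair differing in one place, so this is the first direct reading of a change at this carbon, with the rest of compound 2 kept intact in compound 4. Nothing available explains the size of this step.

One step cannot separate the carbonyl from the change in the alkyl groups on nitrogen. A diethylcarbamoyl group or a (diisopropylamino)methyl group at this carbon would separate them.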